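A few compounds are considered here, and "the series" means these few. Any claim that something is new, unique, unknown or untested is made for them only; others in the source may bear on it.

Compound 1 `COc1ccc(N2CCN(Cn3nc(-c4ccc5c(c4)OCCO5)oc3=S)CC2)cc1`: in a functional assay on HeLa cells (Homo sapiens) for antiproliferative activity, read by MTT assay, with a stated time of 48 h (a lower number here means a stronger inhibitor, a higher number a weaker inhibitor), compound 1 gives > 50000 nM, a limit of the assay.
Compound 2 `Cc1ccc(N2CCN(Cn3nc(-c4ccc5c(c4)OCCO5)oc3=S)CC2)c(C)c1`: compound 2 gives > 50000 nM, again a limit.
Compound 3 `S=c1oc(-c2ccc3c(c2)OCCO3)nn1CN1CCN(c2ccccn2)CC1`: compound 3 gives 25100 nM.

Compound 1 therefore stands at the weak end of this small set, at the limit of > 50000 nM in this assay, at which 2 of the 3 values shown sit. Compound 4 `S=c1oc(-c2ccc3c(c2)OCCO3)nn1CN1CCN(c2ccccc2Cl)CC1` differs from compound 1 in one place: 2-chlorophenyl in place of 4-methoxyphenyl on an amine nitrogen in a ring. Going by the values given here, two measured steps bear on this change of the aryl group on the ring amine. The step that the two limits leave unreadable from compound 1 to compound 2 is unreadable, both values being limits. The step of an at least 1.9-fold lower number from compound 1 to compound 3 (0.29 log units; that floor lies within the scatter) has a floor that lies within the scatter. Among the compounds with values here, neither shows a change of aryl group moving the number beyond the scatter, so compound 4 is expected to remain near the limit, with no step in this assay beyond the scatter. Compound 4 is estimated at 45000 nM, between 18000 nM and 120000 nM, which would mean an at least 1.1-fold lower number from compound 1 to compound 4 (0.04 log units; that floor lies within the scatter).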

Compound 4, half-maximal inhibitory concentration: 37400 nM
The estimate for compound 4 lay 1.2-fold (0.08 log units) above the measured number; measured number inside the range.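

In this assay, going by these compounds alone, the 2-chlorophenyl group on the ring amine gives a second readable number, and the only step between two readable numbers is a 1.5-fold higher number from compound 3 to compound 4 (0.17 log units; within the scatter). The other two steps give only floors, an at least 1.3-fold lower number from compound 1 to compound 4 (0.12 log units; that floor lies within the scatter) and an at least 1.3-fold lower number from compound 2 to compound 4 (0.12 log units; that floor lies within the scatter), so no aryl change shown here moves the number beyond the scatter. Compound 1 and compound 2 remain at a limit: the limit of > 50000 nM in this assay, at which 2 of the 4 values shown sit.

Still open, going by these compounds, is whether any other group on this ring amine, such as a benzyl group or a cyclohexyl ring, would move the number beyond the scatter.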